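The compounds below may be only part of what the source reports. "The series", "measured", "known", "first", "only" and "open" are said of these compounds alone.

Measured compounds:
- compound 1, `NC(=S)N1N=C(c2ccc(N3CCCCC3)cc2)CC1c1ccc(Cl)cc1`, in a functional assay on A-375 cells (Homo sapiens) for antiproliferative activity, read by MTT assay, with a stated time of 72 h (on this read-out lower numbers stand for stronger inhibition and higher numbers for weaker inhibition), gives > 100000 nM
- compound 2, `Clc1ccc(C2CC(c3ccc(N4CCCCC4)cc3)=NN2c2nc(-c3ccccc3)cs2)cc1`, in this assay gives 65800 nM

The value of compound 1 is a limit of the assay and not a number. Compound 2 therefore stands as the only number shown; the one other value given is a limit. The step between them, an at least 1.5-fold lower number from compound 1 to compound 2 (0.18 log units; that floor lies within the scatter), replaces a small group on the amine nitrogen in a ring with a larger two-ring group, and its floor lies within the scatter.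

Compound 3, `O=[N+]([O-])c1ccc(-c2csc(N3N=C(c4ccc(N5CCCCC5)cc4)CC3c3ccc(Cl)cc3)n2)cc1`, carries one further change from compound 2: nitro in place of hydrogen on an aromatic carbon. In words, nitro in place of hydrogen on an aromatic carbon. Among the measured compounds shown here, no measured step in this assay touches this part of the structure, and the one step that is known, from compound 1 to compound 2, concerns the group on the ring nitrogen and not the ring where the nitro enters. Nothing here points to a direction, so for compound 3 the expected step in this assay is a 1.3-fold lower number from compound 2 to compound 3 (0.12 log units; within the scatter), none beyond the scatter. Compound 3 is therefore estimated at 50000 nM in this assay, within a range of 15000 nM to 150000 nM.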

Compound 3, half-maximal inhibitory concentration: > 100000 nM
Compound 3 gave a limit, no number (the forecaster's own chance of this, stated with the estimate: 30%); at least 2.0-fold (0.30 log units) between middle value and limit.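

Moving from phenyl to 4-nitrophenyl is the first change shown on this outer ring, and it gives an at least 1.5-fold higher number from compound 2 to compound 3 (0.18 log units; that floor lies within the scatter). Nitro at this place therefore brings no visible gain in this assay, yet the step cannot be told apart from no change, and only its floor is known, so its true size stays open. Compound 3 gives > 100000 nM, which is a limit of the assay and not a number, and this position can be read only weakly, because most of the series sits at that same limit: the limit of > 100000 nM in this assay, at which 2 of the 3 values shown sit.

The compounds shown leave open whether a different group on this carbon, such as an amine, a methoxy group or a carboxylic acid, would give a lower number than compound 2 or a measurable number of any kind. They also leave open whether nitro on another carbon of the same ring would give the same result as it does here.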